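The compounds below may be only part of what the source reports. "The series", "measured", "known", "first", "only" and "open" are said of these compounds alone.

Three compounds share one core and differ only in the group attached to the amine nitrogen in the ring. Compound 1 `Nc1ccccc1NC(=O)c1ccc(CSC(=S)N2CCN(Cc3ccccn3)CC2)cc1` carries a (pyridin-2-yl)methyl there, compound 2 `Nc1ccccc1NC(=O)c1ccc(CSC(=S)N2CCN(c3ccc(F)cc3)CC2)cc1` a 4-fluorophenyl, and compound 3 `Nc1ccccc1NC(=O)c1ccc(CSC(=S)N2CCN(Cc3cccnc3)CC2)cc1` a (pyridin-3-yl)methyl. In a functional assay on A-375 cells (Homo sapiens) for antiproliferative activity, read by CCK-8 assay, with a stated time of 72 h, tested at 2 uM (a lower number here means a weaker effect, a higher number a stronger effect of the compound at the concentration tested), compound 1 gives 20.7% and compound 2 gives 20.9%, a pair that sits within the scatter of each other a number 0.2 percentage points higher from compound 1 to compound 2 (within the scatter). Compound 3 gives 31.5% in this assay and so stands highest of the three, its step from compound 1 being a number 10.8 percentage points higher from compound 1 to compound 3 (beyond the scatter) and its step from compound 2 being a number 10.6 percentage points higher from compound 2 to compound 3 (beyond the scatter).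

Compound 4 `Nc1ccccc1NC(=O)c1ccc(CSC(=S)N2CCN(Cc3ccccc3)CC2)cc1` arises from compound 3 by a single change: phenyl in place of pyridin-3-yl on a saturated chain carbon bound to an amine nitrogen in a ring. Within the data shown here, the step that bears most directly on it is the one from compound 1 to compound 3, where the ring on that same saturated chain carbon was exchanged and the result was a number 10.8 percentage points higher from compound 1 to compound 3 (beyond the scatter). That step shows that changing the ring at this place can shift the read-out by a modest amount. With the nitrogen of the ring gone entirely, the most cautious expectation is a modest drop back toward the values of compound 1 and compound 2, so for compound 4 the expected step in this assay is a number 7.5 percentage points lower from compound 3 to compound 4 (within the scatter). Compound 4 is therefore estimated at 24%, within a range from 12% to 36%.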

Compound 4, a percentage reported as inhibition, at one concentration (the size of the read-out at that concentration, not a potency): 10.6%
Estimate against measurement, compound 4: 13.4 percentage points above; measured number below the stated range.
By their numbers in this assay, from the lowest: compound 4; then compounds 1 and 2 (each within the scatter of the next); then compound 3.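

Replacing the ring nitrogen of the pyridin-3-yl with a carbon, on the same saturated chain carbon, lowers the read-out in this assay (a number 20.9 percentage points lower from compound 3 to compound 4 (beyond the scatter)), so the ring nitrogen matters at this place, and not only where it sits in the ring, which was all that compound 1 and compound 3 could show. The benzyl group of compound 4 also falls short of the (pyridin-2-yl)methyl group (a number 10.1 percentage points lower from compound 1 to compound 4 (beyond the scatter)) and of the 4-fluorophenyl group (a number 10.3 percentage points lower from compound 2 to compound 4 (beyond the scatter)), which makes compound 4 the weakest of the four at the concentration tested, although compound 2 goes against any simple rule that a carbon-only ring gives a low number. Nothing available here explains why this single atom makes such a difference.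

From the compounds shown here alone, it remains open whether a (pyridin-4-yl)methyl group, or a benzyl group carrying an amine or a carboxylic acid on its ring, would stand nearer compound 3 or compound 4. Whether a longer chain between the ring and the amine nitrogen would preserve the higher number of compound 3 is equally unknown, and a reading at one concentration gives no potency for any of these compounds.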